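A few compounds are considered here, and "the series" means these few. Any claim that something is new, unique, unknown or untested is made for them only; others in the source may bear on it.

Measured so far in an ADME assay (liver) for metabolic stability, with Liver microsome (Rattus norvegicus) as the target, using microsomes; a higher number here means faster removal of the compound, a lower number slower removal:
- compound 1 `COc1ccc2c(-c3ccccc3)nn(-c3nc(C(=O)O)cs3)c2c1` gives 196 mL/min/kg
- compound 2 `Nc1ccc2c(-c3ccccc3)nn(-c3nc(C(=O)O)cs3)c2c1` gives 208 mL/min/kg
- compound 3 `O=C(O)c1csc(-n2nc(-c3ccc(F)cc3)c3ccccc32)n1` gives 278 mL/min/kg

Compound 3 lies within the scatter of both compound 1 and compound 2, and the three values sit at one level. Compound 4 `O=C(O)c1csc(-n2nc(-c3ccc(C(F)(F)F)cc3)c3ccccc32)n1` carries trifluoromethyl in place of fluoro on an aromatic carbon para to a large group. Among the compounds with values here, the one measured step of a 1.1-fold higher number from compound 1 to compound 2 (0.03 log units; within the scatter) concerns other groups and bears only loosely on this change. Within the data shown here, no measured pair covers the change itself, and no step beyond the scatter is expected in this assay for compound 4. The estimate amounts to an expected 1.1-fold lower number from compound 3 to compound 4 (0.05 log units; within the scatter) in this read-out. Compound 4 is expected at 250 mL/min/kg with an estimated range of 135 mL/min/kg to 420 mL/min/kg for this measurement.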

Compound 4, clearance: 809 mL/min/kg
Compound 4: middle estimate off by 3.2-fold (0.51 log units), on the low side; measured number outside the range, above it.
By their numbers in this assay, from the lowest: compounds 1, 2 and 3 (each within the scatter of the next); then compound 4.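

In this assay, trifluoromethyl in place of fluoro on an aromatic carbon para to a large group gives a 2.9-fold higher number from compound 3 to compound 4 (0.46 log units; beyond the scatter) and is the only step shown here beyond the scatter. Compound 1, compound 2 and compound 3 sit at one level, so this position responds to a change in a way those three did not reveal. Nothing measured here accounts for the rise.

Going by these compounds, whether a nitrile or a chloro group at this position would give a similar rise stays open. Also open, on these data alone, is whether the same change would carry over to the cores of compound 1 and compound 2.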